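Working notes: cytotoxicity of compounds 1 to 4

A few compounds are considered here, and "the series" means these few. Any claim that something is new, unique, unknown or untested is made for them only; others in the source may bear on it.

Compound 1 `CC(C)N(Cc1cccc(OCCCCCC(=O)O)c1)C(=O)c1ccc(-c2cccc(Oc3ccccc3)c2)cc1`: > 18700 nM
Compound 2 `CCOC(=O)CCCCCOc1cccc(CN(C(=O)c2ccc(-c3cccnc3)cc2)C(C)C)c1`: > 26000 nM
Compound 3 `CCOC(=O)CCCCCOc1cccc(CN(C(=O)c2ccc(-c3cccc(Oc4ccccc4)c3)cc2)C(C)C)c1`: > 19600 nM

In an ADME assay on BJ cells (Homo sapiens) for cytotoxicity, read by CellTiter-Glo and resazurin assay, with a stated time of 72 h (a lower number here means that less compound is needed, a higher number that more compound is needed for the effect), compound 1 gives > 18700 nM, which is a limit of the assay. Compound 2 gives > 26000 nM, also a limit. Compound 3 gives > 19600 nM, again a limit. Compound 3 therefore stands only at a limit, and the two other values shown are limits as well, so no ordering among the three can be read. Among the compounds with values here, the one step that differs in a single place, a step that the two limits leave unreadable from compound 1 to compound 3, is left unreadable by the two limits.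

Compound 4 `CCOC(=O)CCCCCOc1cccc(CN(C(=O)c2ccc(-c3cccc(Br)c3)cc2)C(C)C)c1` is not yet measured. It differs from compound 3 as follows: bromo in place of phenoxy on an aromatic carbon. Within the data shown here, none of the measured steps touches this change; the only step available concerns the ethyl on the oxygen next to the carbonyl group. With all three values at a limit, the step that the limit leaves unreadable from compound 3 to compound 4 is expected to be no more than the scatter, most likely ending in a further limit. Compound 4 is therefore estimated at 25000 nM, with a range from 10000 nM to 60000 nM.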

Compound 4, half-maximal effective concentration: > 26000 nM
Compound 4 was reported as a limit; the forecaster's own chance of this, stated with the estimate: 75%; at least 1.0-fold (0.01 log units) between middle value and limit.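

In this assay compound 4 gives > 26000 nM, which is a limit. The steps to compound 4 from compound 2 and from compound 3 therefore cannot be read. The compounds shown leave open whether bromo, phenoxy or pyridin-3-yl changes cytotoxicity in this series at all.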